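Amino for Chloro on the Core of Compound 2

This account rests on a few compounds, and the source may have more. Where it says the series, first, only, none or still open, it means among the compounds named here.

Compound 1 `Nc1nn(C(=O)Nc2ccc(Cc3ccccc3)cc2)c2ccccc12` gives 408 nM in a functional assay on NCI-H460 cells (Homo sapiens) for antiproliferative activity, read by sulforhodamine B assay, with a stated time of 48 h; a lower number here means a stronger inhibitor of growth, a higher number a weaker inhibitor of growth.
Compound 2 `Nc1nn(C(=O)Nc2ccc(Cc3ccccc3)cc2)c2ccc(Cl)cc12` gives 64.5 nM in this assay.

Within the data shown here, compound 2 stands at the lower of the two numbers, and the single measured step, a 6.3-fold lower number from compound 1 to compound 2 (0.80 log units; beyond the scatter), lies beyond the scatter. Compound 3 `Nc1ccc2c(c1)c(N)nn2C(=O)Nc1ccc(Cc2ccccc2)cc1` differs from compound 2 by amino in place of chloro on an aromatic carbon. Among the measured compounds shown here, no measured step exchanges chloro for amino, so the one known step bears on it only loosely, showing that this ring position can shift the number. The estimate for compound 3 is therefore a modest move back toward compound 1, a 3.9-fold higher number from compound 2 to compound 3 (0.59 log units; beyond the scatter), giving an expected 250 nM within a range from 60 nM to 1000 nM.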

Compound 3, concentration for 50% growth inhibition: 4640 nM
Compound 3: middle estimate off by 19-fold (1.27 log units), on the low side, outside the stated range (above it).
By their numbers in this assay, from the lowest: compound 2; then compound 1; then compound 3.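

In this assay this ring carbon now separates the three compounds in both directions: chloro lowered the number relative to hydrogen, whereas amino raises it (an 11-fold higher number from compound 1 to compound 3 (1.06 log units; beyond the scatter)). The direct exchange is larger still (a 72-fold higher number from compound 2 to compound 3 (1.86 log units; beyond the scatter)), so the group placed here can strengthen or weaken growth inhibition relative to hydrogen. Nothing available explains this reversal.

Going by these compounds, whether a methoxy group, a fluoro group or a carboxylic acid on this carbon would fall nearer chloro or amino remains open. So does whether amino has the same effect elsewhere on this ring.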